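This account rests on a few compounds, and the source may have more. Where it says the series, first, only, none or still open, it means among the compounds named here.

Working notes on the series in a functional assay on MDA-MB-436 cells (Homo sapiens) for antiproliferative activity, read by MTT assay, with a stated time of 24 h; a lower number here means a stronger inhibitor, a higher number a weaker inhibitor. Compound 1 `O=C(O)CC(NC(=O)c1ccc(F)cc1)c1ccccc1F` gives only a limit in this assay, > 100000 nM. Compound 2 `O=C(O)CC(NC(=O)c1cccc(Br)c1)c1ccccc1F` likewise gives only a limit in this assay, > 100000 nM. The change from compound 1 to compound 2 is 3-bromophenyl in place of 4-fluorophenyl on a carbonyl carbon; the step that the two limits leave unreadable from compound 1 to compound 2 cannot be read because both values sit at the limit of > 100000 nM in this assay, at which 2 of the 3 values shown sit. For the measured compounds named here, compound 3 `O=C(O)CC(NC(=O)c1ccc(F)cc1)c1ccc(Cl)cc1Cl` gives 55800 nM in this assay, the only number among the three measured compounds. The difference between the core of compound 1 and the core of compound 3 is not broken down here. Compound 4 `O=C(O)CC(NC(=O)c1cccc(Br)c1)c1ccc(Cl)cc1Cl` carries the same kind of change: 3-bromophenyl in place of 4-fluorophenyl on a carbonyl carbon; the place is described in the same words as before. The step expected in this assay is a 1.1-fold lower number from compound 3 to compound 4 (0.05 log units; within the scatter). This expectation rests on compound 3 giving 55800 nM and on the earlier step being unreadable. Compound 4 is therefore estimated at 50000 nM, expected between 15000 nM and 150000 nM.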

Compound 4, half-maximal inhibitory concentration: > 100000 nM
Compound 4: only a limit was reported; the forecaster's own chance of this, stated with the estimate: 40%; middle value at least 2.0-fold (0.30 log units) from the limit.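

In this assay compound 4 gives > 100000 nM, which is a limit and not a number. On the core of compound 3, 3-bromophenyl in place of 4-fluorophenyl gives an at least 1.7-fold higher number from compound 3 to compound 4 (0.25 log units; that floor lies within the scatter), a floor that leaves the true size of the step unknown. The same change on the core of compound 1 cannot be read, so the two cores cannot be compared for this change: the limit of > 100000 nM in this assay, at which 3 of the 4 values shown sit.

From the compounds shown here alone, it remains open whether the change would give a readable step on a core where both partners return numbers. Also open, going by these compounds, is how an aminophenyl or a cyanophenyl group on the carbonyl carbon would read in this assay.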